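Shared core series: nitro in place of methyl ester

The source may hold more compounds than are shown below. What is called first, only, known or untested is meant among the compounds shown, and "the series" means these compounds.

Measured so far:
compound 1, `O=C(Nc1ccc(-c2ccc(C(=O)Nc3ccc(C(=O)O)c4ccccc34)cc2)cc1)c1ccc([N+](=O)[O-])cc1`: 15900 nM
compound 2, `COC(=O)c1ccc(C(=O)Nc2ccc(-c3ccc(C(=O)Nc4cccc5cccc(S(=O)(=O)O)c45)cc3)cc2)cc1`: 4500 nM

In an assay for inhibition of CD40-CD40L (Homo sapiens), read by reporter gene assay and flow cytometry, with a stated time of 2 days (on this read-out lower numbers stand for stronger inhibition and higher numbers for weaker inhibition), compound 2 gives 4500 nM, the lowest of the two numbers shown; compound 1 gives 15900 nM, a higher number beyond the scatter. Compound 3, `O=C(Nc1ccc(-c2ccc(C(=O)Nc3cccc4cccc(S(=O)(=O)O)c34)cc2)cc1)c1ccc([N+](=O)[O-])cc1`, is not yet measured. It differs from compound 2 by nitro in place of methoxycarbonyl on an aromatic carbon. Going by the values given here, compound 1 also carries the nitro group, but it differs from compound 2 in a second place as well, so no single-point step for this change is known. The step from compound 2 to compound 3 is expected to be small, at most modestly upward: a 1.6-fold higher number from compound 2 to compound 3 (0.19 log units; within the scatter). Compound 3 is estimated at 7000 nM, within 2000 nM to 25000 nM.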

Compound 3, half-maximal inhibitory concentration in the CD40-CD40L assay: 13200 nM
Compound 3: the middle estimate sits 1.9-fold (0.28 log units) below what was measured; measured number inside the range.
By their numbers in the CD40-CD40L assay, from the lowest: compound 2; then compounds 3 and 1 (each within the scatter of the next).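

Replacing methoxycarbonyl with nitro at this aromatic carbon, para to a large group, weakens inhibition in the CD40-CD40L assay (a 2.9-fold higher number from compound 2 to compound 3 (0.47 log units; beyond the scatter)). Going by these compounds alone, this is the first single-point reading of the change, which compound 1, differing in a second place, could not give. The same change also lowers the number in a physicochemical assay for solubility (on this read-out higher numbers stand for higher solubility and lower numbers for lower solubility), and there the step is the larger one: the measured solubility of compound 2, 240000 nM, and of compound 3, 7000 nM, a 34-fold lower number (1.54 log units; beyond the scatter). In the physicochemical assay compound 2 gives 240000 nM and compound 3 gives 7000 nM.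

Whether the two steps are connected cannot be told from this one pair. From the compounds shown here alone, how the CD40-CD40L assay and the physicochemical assay read for an amine or a nitrile at this position also stays open.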